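Aminoalkylamine in place of chloro on the shared core

The source may report more compounds than this note shows. Statements on the series, on what has been measured and on what is new or still open speak of the compounds shown alone.

Compound 1 `CCCCCCOc1ccc2c(Cl)ccnc2c1` and compound 2 `CC(C)COc1ccc2c(Cl)ccnc2c1` share a core and differ only in the alkoxy chain. In a functional assay on HCT-116 cells (Homo sapiens) for cytotoxicity, read by MTT assay, with a stated time of 48 h (a lower number here means a stronger inhibitor, a higher number a weaker inhibitor), compound 1 gives 2440 nM, and compound 2 gives 2490 nM. Within the data shown here, the single measured step, a 1.0-fold higher number from compound 1 to compound 2 (0.01 log units; within the scatter), shows that isopropyl in place of pentyl on the saturated chain carbon bound to the ring oxygen leaves the read-out unchanged within the scatter. Compound 1 stands at the lower of the two numbers, with compound 2 within the scatter of it, so neither can be called the stronger.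

Compound 3 `CCCCCCOc1ccc2c(NCCN(C)C)ccnc2c1` keeps the hexyloxy chain of compound 1 and changes the other substituent: (2-(dimethylamino)ethyl)amino in place of chloro on an aromatic carbon. Among the measured compounds shown here, no measured step touches this position; the one step known concerns the chain and bears only indirectly, in that the chain appears tolerant. The size and direction of the step are therefore open. Compound 3 is expected to give 1200 nM, with a range of 300 nM to 5000 nM, in this assay. The expected step is a 2.0-fold lower number from compound 1 to compound 3 (0.31 log units; beyond the scatter), a cautious estimate leaning to a lower number.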

Compound 3, half-maximal inhibitory concentration: 850 nM
The estimate for compound 3 lay 1.4-fold (0.15 log units) above the measured number, within the range that was stated.
By their numbers in this assay, from the lowest: compound 3; then compounds 1 and 2 (each within the scatter of the next).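

The position opposite the ring nitrogen moves the read-out where the alkoxy chain did not: in this assay, (2-(dimethylamino)ethyl)amino in place of chloro gives a 2.9-fold lower number from compound 1 to compound 3 (0.46 log units; beyond the scatter), a modest step but the first in the series beyond the scatter. Chloro is therefore not needed at this aromatic carbon for cytotoxicity in these cells, and a side chain of 6 heavy atoms, carrying 1 hydrogen-bond donor and 2 hydrogen-bond acceptors, is tolerated there in place of a single chlorine. Nothing at hand gives a measured reason for the lower number with this change.

Still open, going by these compounds, is which part of the new group carries the step, the amino nitrogen on the aromatic carbon or the terminal dimethylamino: a longer chain between the two nitrogens, or a morpholine in place of the dimethylamino end, would help to separate the two. Also open, on these data alone, is whether the flat response to the alkoxy chain seen between the two chloro compounds holds once this aminoalkylamine occupies the position.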